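Isopropoxy for Methyl on the Fused Ring of Compound 1

The source may report more compounds than this note shows. Statements on the series, on what has been measured and on what is new or still open speak of the compounds shown alone.

Compound 1 `Cc1cc2c(cc1NS(=O)(=O)c1ccc(-c3ccc(Cl)cc3)cc1)CCN(C)CC2` was tested in an assay on isolated protein for displacement of a labelled ligand from 5-hydroxytryptamine receptor 6 (Homo sapiens), read by radioligand binding (on this read-out lower numbers stand for stronger inhibition and higher numbers for weaker inhibition), where compound 1 gives 15.9 nM, the highest of the three numbers in hand. Compound 2 `Cc1ccc(-c2ccc(S(=O)(=O)Nc3ccc4c(c3)CCN(C)CC4)cc2)s1` gives 6.31 nM, a lower number beyond the scatter, and compound 3 `Cc1cc(S(=O)(=O)Nc2ccc3c(c2)CCN(C)CC3)ccc1-c1ccc(Cl)cc1` gives 5.01 nM, the furthest from compound 1 and also beyond the scatter. Compound 4 `CC(C)Oc1cc2c(cc1NS(=O)(=O)c1ccc(-c3ccc(Cl)cc3)cc1)CCN(C)CC2` has not yet been measured. It differs from compound 1 by isopropoxy in place of methyl on an aromatic carbon, on an aromatic carbon of the fused core, ortho to a large group. Going by the values given here, no measured pair shows this change, and the direction remains open; a step of modest size, not clearly beyond the scatter, is expected in this assay, estimated as a 1.3-fold lower number from compound 1 to compound 4 (0.12 log units; within the scatter). Compound 4 is expected to give 12 nM, with a range from 3 nM to 50 nM.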

Compound 4, inhibition constant: 31.6 nM
The estimate for compound 4 lay 2.6-fold (0.42 log units) below the measured number, within the range that was stated.
By their numbers in this assay, from the lowest: compounds 3 and 2 (each within the scatter of the next); then compounds 1 and 4 (each within the scatter of the next).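

In this assay, isopropoxy in place of methyl on this aromatic carbon, ortho to a large group, gives a 2.0-fold higher number from compound 1 to compound 4 (0.30 log units; within the scatter). Going by these compounds alone, this is the first measured pair at this position, and it shows that the position carries the larger isopropoxy group, with its added hydrogen-bond acceptor, without a step beyond the scatter. Nothing measured here accounts for the result.

The compounds shown leave open whether the position would also carry an amine, a carboxylic acid or a longer alkoxy chain. They also leave open whether methoxy would fit the same picture.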